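Moving the Trifluoromethyl Group Around the Phenyl Ring

The compounds below may be only part of what the source reports. "The series", "measured", "known", "first", "only" and "open" are said of these compounds alone.

Compound 3 `Oc1cccc(-c2cc(-c3ccccc3C(F)(F)F)cc(-c3ccccc3O)n2)c1` carries a 2-(trifluoromethyl)phenyl group on the shared core. Among the compounds with values here, in a functional assay on T47D cells (Homo sapiens) for inhibition (on this read-out lower numbers stand for stronger inhibition and higher numbers for weaker inhibition), compound 3 gives 5680 nM, the only true number among the three compounds measured so far. Compound 1 `Oc1cccc(-c2cc(-c3ccc(F)cc3)cc(-c3ccccc3O)n2)c1`, which has a 4-fluorophenyl group in the same place, reaches only the limit of > 50000 nM in this assay. Compound 2 `Oc1ccccc1-c1cc(-c2ccc(C(F)(F)F)cc2)cc(-c2ccccc2O)n1`, which has a 4-(trifluoromethyl)phenyl group together with two 2-hydroxyphenyl groups, also gives only the limit of > 50000 nM in this assay.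

Compound 4 `Oc1cccc(-c2cc(-c3ccc(C(F)(F)F)cc3)cc(-c3ccccc3O)n2)c1` has not yet been measured. It differs from compound 3 by 4-(trifluoromethyl)phenyl in place of 2-(trifluoromethyl)phenyl on an aromatic carbon. Within the data shown here, one measured step bears on this change: an at least 8.8-fold lower number from compound 1 to compound 3 (0.94 log units; beyond the scatter), a step that starts from a limit, so only its lower bound is known. The 2-(trifluoromethyl)phenyl group is the one arrangement that has produced a measurable number, while the two compounds carrying a group on the far side of the phenyl ring both sit at the limit of > 50000 nM in this assay, at which 2 of the 3 values shown sit. Because the limit of > 50000 nM in this assay, at which 2 of the 3 values shown sit, holds compound 1 and compound 2, compound 4 is expected to move back toward weaker inhibition, and a limit is likely. The expected step of a 5.3-fold higher number from compound 3 to compound 4 (0.72 log units; beyond the scatter) is an increase in the number beyond the scatter. For compound 4 the estimated value is 30000 nM, with a range from 8000 nM to 120000 nM.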

Compound 4, half-maximal inhibitory concentration: > 50000 nM
Compound 4: no number, only a limit; the forecaster's own chance of this, stated with the estimate: 55%; middle value at least 1.6-fold (0.22 log units) from the limit.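

With the same atoms joined differently, moving from the 2-(trifluoromethyl)phenyl group to the 4-(trifluoromethyl)phenyl group gives an at least 8.8-fold higher number from compound 3 to compound 4 (0.94 log units; beyond the scatter) in this assay, so where the trifluoromethyl group sits on this phenyl ring matters here. Compound 4 carries a trifluoromethyl group and still gives only a limit, which shows that having this group on the phenyl ring is not enough for a measurable number, something the earlier step from a fluoro compound could not separate. The steps to compound 4 from compound 1 and from compound 2 cannot be read, with both ends of each step at the same limit: the limit of > 50000 nM in this assay, at which 3 of the 4 values shown sit.

As far as these compounds go, it remains open whether a methoxy group or a chlorine atom in place of the trifluoromethyl group of compound 3 would keep a measurable number, or whether the trifluoromethyl group itself is needed. It is also open whether exchanging the 3-hydroxyphenyl group of compound 3 for a 2-hydroxyphenyl group would change the number, as the only comparison of these two groups shown here is unreadable.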